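The source may report more compounds than this note shows. Statements on the series, on what has been measured and on what is new or still open speak of the compounds shown alone.

In an ADME assay on THP-1 cells (Homo sapiens) for cytotoxicity, read by flow cytometry and propidium iodide staining, with a stated time of 72 h (a higher number here means a weaker inhibitor, a lower number a stronger inhibitor), compound 2 `COc1c(-c2ccccc2)oc2ccc(NC(C)=O)cc2c1=O` has no number, only a limit of > 125000 nM. Compound 3 `COc1c(-c2ccc(F)cc2)oc2ccc(NC(C)=O)cc2c1=O` likewise gives only a limit, > 125000 nM. These two results make up (the limit of > 125000 nM in this assay, at which 2 of the 3 values shown sit). Compound 1 `Nc1ccc2oc(-c3ccccc3)c(O)c(=O)c2c1` is the only one of the three with a measured number, 27000 nM.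

Compound 4 `COc1c(-c2ccccc2)oc2ccc(N)cc2c1=O` is reached from compound 2 by one change: hydrogen in place of acetyl on a nitrogen on an aromatic ring. In short, hydrogen takes the place of acetyl on a nitrogen on an aromatic ring, turning acetamido to amino.

Going by the values given here, the one measured step, a step that the two limits leave unreadable from compound 2 to compound 3, concerns fluoro in place of hydrogen on an aromatic carbon, so it offers no size to carry over. The expectation therefore leans on compound 1 and its 27000 nM, and it points to a stronger reading in this assay, of uncertain size. The expected change is an at least 2.5-fold lower number from compound 2 to compound 4 (0.39 log units; beyond the scatter). For compound 4 the estimated value is 50000 nM, with an expected range from 15000 nM to 125000 nM.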

Compound 4, half-maximal inhibitory concentration: 74000 nM
Beside the measured number, compound 4's estimate is 1.5-fold (0.17 log units) below it, and the stated range covers the measured number.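

In this assay, the nitrogen on the aromatic ring gives its first readable change, with hydrogen in place of acetyl: an at least 1.6-fold lower number from compound 2 to compound 4 (0.22 log units; that floor lies within the scatter). Compound 2 gives only a limit, so this step has a floor and no measured size: the limit of > 125000 nM in this assay, at which 2 of the 4 values shown sit. With the amino group in place, methyl in place of hydrogen on an oxygen on an aromatic ring can also be read, as a 2.7-fold higher number from compound 1 to compound 4 (0.44 log units; beyond the scatter).

From the compounds shown here alone, the step that adds fluoro to the aromatic carbon still cannot be read, and whether fluoro would show any change alongside the amino group remains open. Also open, going by these compounds, is what other groups on the nitrogen, such as a methyl or a propanoyl group, or a longer chain on the oxygen, such as an ethyl group, would give.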